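A few compounds are considered here, and "the series" means these few. Any claim that something is new, unique, unknown or untested is made for them only; others in the source may bear on it.

Going by the values given here, in a functional assay on PC-12 cells (Rattus norvegicus) for cytotoxicity, read by MTT assay, with a stated time of 24 h (on this read-out lower numbers stand for an effect already at smaller amounts and higher numbers for an effect only at larger amounts of compound), three compounds have numbers so far. Compound 1 (`COc1ccc(N2CCN(CC#CCOC(=O)c3sc4ncnc(N5CCCCC5)c4c3C)CC2)cc1`) gives 35.3 ug/mL on this read-out, and compound 2 (`COc1cccc(N2CCN(CC#CCOC(=O)c3sc4ncnc(N5CCCCC5)c4c3C)CC2)c1`) gives 40.4 ug/mL on the same read-out. Compound 3 (`Cc1c(-c2nnc(-c3ccccc3)o2)sc2ncnc(N3CCCCC3)c12`), which carries a different group on the shared core, gives 22.1 ug/mL and stands within the usual scatter of both others, so the three values cannot be ranked.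

Compound 4 (`Cc1c(-c2nnc(-c3ccc(Cl)cc3)o2)sc2ncnc(N3CCCCC3)c12`) is compound 3 with a single change: chloro in place of hydrogen on an aromatic carbon. In other words, phenyl becomes 4-chlorophenyl.

Among the compounds with values here, only one measured step links compounds that differ in one place: a 1.1-fold higher number from compound 1 to compound 2 (0.06 log units; within the scatter), which lies within the scatter. That step concerns 3-methoxyphenyl in place of 4-methoxyphenyl, so it bears on the present change only loosely. It does show one small structural change passing without a visible shift in this assay on this set. Within the data shown here, no measured pair tests chloro in place of hydrogen on an aromatic carbon, and no direction can be drawn from the data. No shift beyond the scatter is therefore expected. The expected step is a 1.1-fold lower number from compound 3 to compound 4 (0.04 log units; within the scatter), and it carries no firm direction. The estimated value for compound 4 is 20 ug/mL, with an expected range from 10 ug/mL to 40 ug/mL as the likely span.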

Compound 4, half-maximal effective concentration: 21.8 ug/mL
Estimate against measurement, compound 4: 1.1-fold (0.04 log units) below, and the stated range covers the measured number.
By their numbers in this assay, from the lowest: compounds 4, 3, 1 and 2 (each within the scatter of the next).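

Going by these compounds alone, the step from phenyl to 4-chlorophenyl reads as a 1.0-fold lower number from compound 3 to compound 4 (0.01 log units; within the scatter) in this assay, and it is the first direct test in this set of chloro in place of hydrogen on an aromatic carbon. The earlier step moved a methoxy group on a different part of a different series, whereas this one adds a single chlorine on the six-membered aromatic ring of carbon only, para to a large group, and the read-out shows no visible shift there. Nothing available explains why the number stays within the scatter, so this pair records an outcome and not a reason.

The compounds shown leave open whether other groups at this same place, such as an amine, a carboxylic acid or a longer alkyl chain, would also pass without a shift beyond the scatter. They also leave open whether chloro on the other carbons of this ring, or on the methoxyphenyl ring of the compounds with the longer chain on the shared core, would read the same way.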